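The source may report more compounds than this note shows. Statements on the series, on what has been measured and on what is new or still open speak of the compounds shown alone.

Two vinyl sulfones with a chloro-substituted aryl sulfonyl group have been measured in an assay on U2OS cells for activation of nuclear factor erythroid 2-related factor 2 (Homo sapiens), read by beta-arrestin recruitment, with a stated time of 6 h; on this read-out lower numbers stand for an effect already at smaller amounts and higher numbers for an effect only at larger amounts of compound. Compound 1, `O=S(=O)(/C=C\c1ncccc1F)c1cccc(Cl)c1`, gives 252 nM in this assay. Compound 2, `O=S(=O)(/C=C/c1ncccc1Cl)c1cccc(Cl)c1`, gives 46 nM in this assay, the lowest of the two numbers; compound 1 is the nearest, with a number higher by an amount beyond the usual scatter. The two measured compounds differ in more than one place, so their gap is reported only as what the two values show.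

Compound 3, `O=S(=O)(/C=C\c1ncccc1Cl)c1cccc(Cl)c1`, is not yet measured. From compound 2 it differs thus: the two compounds have the same atoms and bonds and differ only in configuration as drawn: 1 of 1 stereo elements differ; a double bond is drawn E in compound 2 and Z in compound 3. In the absence of a single-change step in this assay, the shift from compound 2 to compound 3 is expected to raise the number, by an amount beyond the scatter, with compound 1 as the only point of reference for the Z drawing. For compound 3 the estimated value in this assay is 200 nM, with a range of 60 nM to 800 nM, an expected step of a 4.3-fold higher number from compound 2 to compound 3 (0.64 log units; beyond the scatter) from its comparator.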

Compound 3, half-maximal effective concentration: 290 nM
The estimate for compound 3 lay 1.5-fold (0.16 log units) below the measured number; low and high end bracket the measured number.
By their numbers in this assay, from the lowest: compound 2; then compounds 1 and 3 (each within the scatter of the next).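

In this assay, the drawing of the double bond alone now carries a real gap, a 6.3-fold higher number from compound 2 to compound 3 (0.80 log units; beyond the scatter), and the comparison isolates that single feature: the fact that compounds 2 and 3 differ only in the configuration as drawn. With the double bond drawn Z, chloro in place of fluoro on an aromatic carbon gives a 1.2-fold higher number from compound 1 to compound 3 (0.06 log units; within the scatter), so this swap does not separate the two compounds. For the compounds shown here, of the two single changes read here, only the one at the double bond moves the number beyond the scatter.

The compounds shown leave open whether chloro in place of fluoro reads the same way with the double bond drawn E, since only the Z pair can be compared. They also leave open how a methoxy group or a nitrile on that aromatic carbon would read in this assay, and whether the E preference would hold with such a group.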